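The source may hold more compounds than are shown below. What is called first, only, known or untested is meant among the compounds shown, and "the series" means these compounds.

In a functional assay on cells (Lymphocyte, Homo sapiens), read by trypan blue exclusion, with a stated time of 16 h, tested at 0.1 uM (on this read-out lower numbers stand for a weaker effect and higher numbers for a stronger effect at the one concentration tested), compound 2 `CCCCCCCCCCc1nc(N(C)C)c(C)c(C)c1O` gives 36%, the lower of the two numbers recorded so far; the other, compound 1 `CCCCCCCCCCCCCCCCc1nc(N2CCC2)c(C)c(C)c1O`, gives 54% in this assay, and the gap between them lies beyond the scatter. Compound 1 and compound 2 differ in two places at once, so the two values can only be set side by side, not read as a single step.

Compound 3 `CCCCCCCCCCCCCCCCc1nc(N(C)C)c(C)c(C)c1O` has not been measured in this assay. It differs from compound 2 by hexyl in place of hydrogen on a saturated chain carbon, ten or more bonds along the chain from an aromatic carbon. For the measured compounds named here, no measured pair shows this exact change on its own. Compound 3 carries the same chain as compound 1, and its remaining parts match compound 2.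

Because compound 1 gives 54% with the longer chain, an increase from compound 2 to compound 3 is expected in this assay, estimated as a number 14 percentage points higher from compound 2 to compound 3 (beyond the scatter), somewhat larger than the scatter. For compound 3 the expected value in this assay is 50%, with a range from 30% to 70%.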

Compound 3, a percentage reported as activity, at one concentration (the size of the read-out at that concentration, not a potency): 80%
The estimate for compound 3 lay 30 percentage points below the measured number; measured number outside the range, above it.
By their numbers in this assay, from the lowest: compound 2; then compound 1; then compound 3.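

In this assay, for the compounds shown here, the earlier compounds could only be set side by side, but this result gives the first reading of each change on its own. Hexyl in place of hydrogen on a saturated chain carbon gives a number 44 percentage points higher from compound 2 to compound 3 (beyond the scatter) and is a large step, so with dimethylamino held fixed the longer chain goes with a much stronger effect at the one concentration tested. With the longer chain held fixed, dimethylamino in place of azetidin-1-yl on an aromatic carbon gives a number 26 percentage points higher from compound 1 to compound 3 (beyond the scatter) as a modest step, which shows that the group on the aromatic carbon also counts and leaves compound 3 highest of the three; nothing on hand accounts for either step.

From the compounds shown here alone, whether the chain step keeps its size with azetidin-1-yl on the aromatic carbon remains open, and so does the course of the read-out between and beyond these chain lengths, for instance with a longer chain. Going by these compounds, it is equally open how a larger cyclic amine such as piperidin-1-yl would compare with dimethylamino on the aromatic carbon.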